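The compounds below may be only part of what the source reports. "The series", "measured", "known", "first", "only" and "open" are said of these compounds alone.

Measured in a functional assay on HT-29 cells (Homo sapiens) for inhibition, read by MTT assay, with a stated time of 48 h; on this read-out higher numbers stand for weaker inhibition and lower numbers for stronger inhibition:

compound 1 `COc1ccc(-n2c(SCc3ccccc3)nnc2-c2cc(OC)c(OC)c(OC)c2)cc1` gives a limit of the assay, > 60000 nM
compound 2 `COc1ccc(C(=O)CSc2nnc(-c3cc(OC)c(OC)c(OC)c3)n2-c2ccc(OC)cc2)cc1` gives a limit of the assay, > 60000 nM
compound 3 `COc1cc(-c2nnc(SCc3ccccc3)n2-c2ccc(N(C)C)cc2)cc(OC)c1OC` gives a limit of the assay, > 60000 nM

Every value shown is a limit, not a number: in each case the half-maximal inhibitory concentration was not reached at the highest concentration tested, so none of the three compounds can be ranked against another. Compound 3 therefore stands at the same limit as its two companions, which is where (the limit of > 60000 nM in this assay, at which 3 of the 3 values shown sit). The step that the two limits leave unreadable from compound 1 to compound 3 and the step that the two limits leave unreadable from compound 1 to compound 2 are both unreadable: with a limit at each end, neither their size nor their direction can be known.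

Compound 4 `COc1cc(-c2nnc(SCC(=O)C3CC3)n2-c2ccc(N(C)C)cc2)cc(OC)c1OC` differs from compound 3 by cyclopropylcarbonyl in place of phenyl on a saturated chain carbon bound to a sulfur. For the measured compounds named here, the only measured step that resembles this change is a step that the two limits leave unreadable from compound 1 to compound 2, in which a carbonyl-bearing group likewise replaced phenyl on the saturated chain carbon bound to a sulfur; it gave no readable size. Going by the values given here, with no measured step to lean on, and every shared-core compound sitting at the limit, the expectation for compound 4 is that it too stays near that limit, so the step that the limit leaves unreadable from compound 3 to compound 4 is expected to carry no readable change. For compound 4 the estimate is 70000 nM, with a range from 20000 nM to 200000 nM.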

Compound 4, half-maximal inhibitory concentration: > 60000 nM
Compound 4: no number, only a limit; the forecaster's own chance of this, stated with the estimate: 75%; the middle value does not contradict the limit.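

Compound 3 and compound 4 both end at a limit of the assay rather than a number, so the step between them cannot be read, in either size or direction: the limit of > 60000 nM in this assay, at which 4 of the 4 values shown sit.

The compounds shown leave open which change to the shared core, if any, would give a measured number in place of a limit.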